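One More Carbon on the Acyl Chain

This account rests on a few compounds, and the source may have more. Where it says the series, first, only, none or still open, it means among the compounds named here.

Of the compounds shown here, two have been measured in an assay on isolated protein for inhibition of Nitric oxide synthase, inducible (Homo sapiens), read by scintillation counting, with a stated time of 30 min, tested at 50 uM; a higher number here means more inhibition at the concentration tested (going by the name of the read-out), a lower number less inhibition. Compound 1 `CCCC(=O)N1N=C(c2cc(OC)ccc2N)SC1(C)C` gives 91.1%. Compound 2 `CCC(=O)N1N=C(c2ccccc2N)SC1(C)C` gives 19.2%, the lower of the two numbers, and its gap to compound 1 lies beyond the usual scatter. These two compounds differ in more than one place: compound 1 carries a methoxy group that compound 2 lacks, and its acyl chain is one carbon longer. Among the compounds with values here, no step between measured compounds that differ in a single place is available, so the two values alone cannot show how much of the gap belongs to each change.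

Compound 3 `CCCC(=O)N1N=C(c2ccccc2N)SC1(C)C` has not yet been measured. Relative to compound 2 the change is methyl in place of hydrogen on a saturated chain carbon, two bonds along the chain from a carbonyl carbon. This takes over only the chain part of the difference between compound 2 and compound 1 and leaves the methoxy group out. The step from compound 2 to compound 3 is expected to be upward, of size a number 25.8 percentage points higher from compound 2 to compound 3 (beyond the scatter), though with much uncertainty. For compound 3 the estimated value in this assay is 45%, within a range from 15% to 85%.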

Compound 3, a percentage reported as inhibition, at one concentration (the size of the read-out at that concentration, not a potency): 35.2%
Estimate against measurement, compound 3: 9.8 percentage points above; the range from low to high includes it.
By their numbers in this assay, from the lowest: compound 2; then compound 3; then compound 1.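

In this assay the chain change can now be read alone: methyl in place of hydrogen on a saturated chain carbon, two bonds along the chain from a carbonyl carbon, turning propanoyl into propylcarbonyl, gives a number 16 percentage points higher from compound 2 to compound 3 (beyond the scatter) with nothing else in the structure altered. Within the data shown here, the methoxy change can also be read alone for the first time: hydrogen in place of methoxy on an aromatic carbon gives a number 55.9 percentage points lower from compound 1 to compound 3 (beyond the scatter) on the same propylcarbonyl chain, so the large part of the original gap goes with the methoxy group and the modest part with the extra chain carbon. No measurement is available that explains either step.

On these data alone, the methoxy step is known only on the propylcarbonyl chain, so its size on the propanoyl chain of compound 2 remains open. Also open, as far as these compounds go, are whether a longer chain such as pentanoyl would extend the rise seen with the added methyl, and whether an ethoxy or a hydroxyl group on that aromatic carbon would do what methoxy does.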